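The compounds below may be only part of what the source reports. "The series", "measured", "known", "first", "only" and "open" are said of these compounds alone.

Working notes on the series. Compound 2 `CC/C=C\C/C=C\C/C=C\CCCCCCCc1cc(=O)c2c(O)cc(OCOC)cc2o1` gives 17500 nM in a functional assay on MCF7 cells (Homo sapiens) for antiproliferative activity, read by MTT assay; a lower number here means a stronger inhibitor, a higher number a weaker inhibitor. Compound 1 `CCCC/C=C\CCCCCCCCCc1cc(=O)c2c(O)cc(OCOC)cc2o1` returns only a limit in this assay, namely > 67200 nM. The change from compound 2 to compound 1 is a group of 8 heavy atoms (8 carbon; no ring) in place of a group of 10 heavy atoms (10 carbon; no ring), on a saturated chain carbon, seven bonds along the chain from an aromatic carbon; it brings an at least 3.8-fold higher number from compound 2 to compound 1 (0.58 log units; beyond the scatter), the upper end resting on (the limit of > 67200 nM in this assay, at which 1 of the 3 values shown sits). Compound 3 `CC/C=C\C/C=C\C/C=C\CCCCCCCc1cc(=O)c2c(O)c(C)c(O)c(C)c2o1` carries a different core; the difference between the two cores is not broken down here. In this assay compound 3 gives 17500 nM, level with compound 2 at the digits shown. Compound 4 `CCCC/C=C\CCCCCCCCCc1cc(=O)c2c(O)c(C)c(O)c(C)c2o1` relates to compound 3 as compound 1 relates to compound 2: the same change, (a group of 8 heavy atoms (8 carbon; no ring) in place of a group of 10 heavy atoms (10 carbon; no ring), on a saturated chain carbon, seven bonds along the chain from an aromatic carbon). Since the earlier step read an at least 3.8-fold higher number from compound 2 to compound 1 (0.58 log units; beyond the scatter) and compound 3 starts from 17500 nM, a step of a 4.9-fold higher number from compound 3 to compound 4 (0.69 log units; beyond the scatter) is expected. For compound 4 the estimate in this assay is 85000 nM, with a range from 40000 nM to 200000 nM.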

Compound 4, half-maximal inhibitory concentration: > 67200 nM
Compound 4 was reported as a limit; the forecaster's own chance of this, stated with the estimate: 70%; the middle value does not contradict the limit.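

In this assay compound 4 is reported only as a limit, > 67200 nM. Putting oct-3-en-1-yl in place of the 10-carbon group brings an at least 3.8-fold higher number from compound 3 to compound 4 (0.58 log units; beyond the scatter), so the change points the same way on both cores shown: the same change on two cores in this assay, an at least 3.8-fold higher number (0.58 log units; beyond the scatter) from compound 2 to compound 1 and an at least 3.8-fold higher number (0.58 log units; beyond the scatter) from compound 3 to compound 4; the limit leaves it open whether they differ Both steps end at the same limit, so the direction carries over between these two cores, but the true size of each step and any gap between them stay unresolved: the limit of > 67200 nM in this assay, at which 2 of the 4 values shown sit.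

The compounds shown leave open how a longer chain, or a chain ending in a carboxylic acid or an amine, would read in this assay. Going by these compounds, whether the step holds on any further core also remains open.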